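Hydroxy added to the benzyl group of compound 3

This account rests on a few compounds, and the source may have more. Where it says the series, first, only, none or still open, it means among the compounds named here.

In an ADME assay on HEK-293T cells (Homo sapiens) for cytotoxicity, read by CCK-8 assay, with a stated time of 48 h (on this read-out lower numbers stand for stronger inhibition and higher numbers for weaker inhibition), compound 3 (`O=[N+]([O-])c1ccc(NC(=S)NCCNS(=O)(=O)c2ccc(-c3ccccc3OCc3ccccc3)s2)cc1`) gives 8900 nM. Compound 1 (`O=S(=O)(NCCNC(=S)Nc1cccc(Cl)c1)c1ccc(-c2ccccc2OCc2cccc(O)c2)s1`) gives 17400 nM, which lies within the scatter of the number for compound 3. Compound 2 (`O=[N+]([O-])c1ccc(NC(=S)NCCNS(=O)(=O)c2ccc(-c3ccccc3O[C@H]3CC[C@@H](O)CC3)s2)cc1`) gives 20000 nM, which lies beyond the scatter of that number.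

Compound 4 (`O=[N+]([O-])c1ccc(NC(=S)NCCNS(=O)(=O)c2ccc(-c3ccccc3OCc3cccc(O)c3)s2)cc1`) has hydroxy in place of hydrogen on an aromatic carbon of compound 3, meta to a large group, turning benzyl into 3-hydroxybenzyl: hydroxy in place of hydrogen on an aromatic carbon. For the measured compounds named here, no measured step makes this exact change. The closest is a 2.2-fold lower number from compound 2 to compound 3 (0.35 log units; beyond the scatter), with benzyl in place of 4-hydroxycyclohexyl, a modest step. Compound 1 already carries 3-hydroxybenzyl at 17400 nM, but it differs from compound 4 elsewhere as well, so it is only a loose guide.

A small rise in this assay, of about the size of the scatter, is therefore expected: the estimated step is a 1.3-fold higher number from compound 3 to compound 4 (0.13 log units; within the scatter). For compound 4 the estimated value is 12000 nM, with an expected range of 6000 nM to 24000 nM.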

Compound 4, half-maximal inhibitory concentration: > 20000 nM
Compound 4: a limit, no number (the forecaster's own chance of this, stated with the estimate: 5%); at least 1.6-fold (0.22 log units) between middle value and limit.
By their numbers in this assay, from the lowest: compounds 3, 1 and 2 (each within the scatter of the next, the first and the last beyond it).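

In this assay, for the compounds shown here, the pair compound 3 and compound 4 gives the first direct reading of hydroxy in place of hydrogen at this position, meta to a large group, with the rest of the structure unchanged: an at least 2.2-fold higher number from compound 3 to compound 4 (0.35 log units; beyond the scatter). For compound 4, the value > 20000 nM is a limit and not a number, so that step has a floor but no upper size: the limit of > 20000 nM in this assay, at which 1 of the 4 values shown sits. With 3-hydroxybenzyl held, 4-nitrophenyl in place of 3-chlorophenyl gives an at least 1.1-fold higher number from compound 1 to compound 4 (0.06 log units; that floor lies within the scatter). 3-Hydroxybenzyl in place of 4-hydroxycyclohexyl on an oxygen on an aromatic ring gives a number no lower from compound 2 to compound 4 (the limit leaves the size open) and the size of that step cannot be read.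

On these data alone, how far the true value of compound 4 lies from its limit remains open. Also open, as far as these compounds go, is whether methoxy, an amine or a carboxylic acid on the same aromatic carbon would shift the read-out in the same direction as hydroxy.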